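The source may report more compounds than this note shows. Statements on the series, on what has been measured and on what is new or still open speak of the compounds shown alone.

Measured compounds:
- compound 1 `N=c1c2c(-c3ccccc3)c(-c3ccccc3)n(CC3CC3)c2ncn1CC1CCOCC1`; in an ADME assay for permeability, using PAMPA, with a stated time of 30 min, at pH 7.4 (a higher number here means that the compound crosses the layer faster, a lower number that the compound crosses the layer more slowly), compound 1 gives > 1000 10^-6 cm/s, which is a limit of this assay rather than a number.
- compound 2 `COc1ccc(Cn2c(-c3ccccc3)c(-c3ccccc3)c3c(=N)n(CC4CCOCC4)cnc32)cc1`; in this assay compound 2 gives 1270 10^-6 cm/s.

For the measured compounds named here, compound 2 carries the only numerical value in this assay; the one other value shown is a limit. Going by the values given here, the single measured step, a step that the limit leaves unreadable from compound 1 to compound 2, cannot be sized because of the limit of > 1000 10^-6 cm/s in this assay, at which 1 of the 2 values shown sits. Compound 3 `COc1ccc(Cn2c(-c3ccccc3)c(-c3ccccc3)c3c(=N)n(CC4CCCO4)cnc32)cc1` differs from compound 2 by oxolan-2-yl in place of oxan-4-yl on a saturated chain carbon bound to an aromatic nitrogen. Among the compounds with values here, no measured step touches this substituent, so no measured step bears directly on it; the step from compound 1 to compound 2 changes a different group and its size is unreadable. Nothing in the measured values points to a change beyond the scatter, so the estimated step of a 1.1-fold lower number from compound 2 to compound 3 (0.02 log units; within the scatter) is expected to stay within it. Compound 3 is therefore expected to give about 1200 10^-6 cm/s in this assay, in the range 600 10^-6 cm/s to 2400 10^-6 cm/s.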

Compound 3, apparent permeability: > 1000 10^-6 cm/s
Compound 3: only a limit was reported; the forecaster's own chance of this, stated with the estimate: 35%; the middle value is on the limit's open side.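

No step from compound 2 to compound 3 can be read in this assay, because compound 3 also gives only a limit: the limit of > 1000 10^-6 cm/s in this assay, at which 2 of the 3 values shown sit.

On these data alone, whether oxolan-2-yl in place of oxan-4-yl shifts this read-out at all, and in which direction, remains open.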